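The source may hold more compounds than are shown below. What is called first, only, known or untested is meant among the compounds shown, and "the series" means these compounds.

Measured compounds:
Compound 1 `NCCCOc1ccc(CNc2nc3ccc(Oc4ccc(O)cc4)cc3s2)cc1` — in an assay on SH-SY5Y cells for inhibition of Voltage-dependent N-type calcium channel subunit alpha-1B (Homo sapiens), read by FLIPR and calcium flux, with stated times of 600 s and 300 s, in the presence of a further agent that is not named here (on this read-out higher numbers stand for weaker inhibition and lower numbers for stronger inhibition), compound 1 gives 205000 nM.
Compound 2 `NCCCOc1ccc(CNc2nc3ccc(Oc4cccc(C(F)(F)F)c4)cc3s2)cc1` — compound 2 gives 144000 nM.
Compound 3 `N=C(N)NCCCOc1ccc(CNc2nc3ccc(Oc4ccc(O)cc4)cc3s2)cc1` — compound 3 gives 253000 nM.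

Among these three numbers, compound 1 stands second highest. The nearest number belongs to compound 3, and a 1.2-fold higher number from compound 1 to compound 3 (0.09 log units; within the scatter). The furthest belongs to compound 2, and a 1.4-fold lower number from compound 1 to compound 2 (0.15 log units; within the scatter). Both steps, the exchange of the aryl ether and the extension of the chain-end amine, therefore leave the read-out where it was within the scatter of this kind of measurement.

Compound 4 `CN(Cc1ccc(OCCCN)cc1)c1nc2ccc(Oc3ccc(O)cc3)cc2s1` differs from compound 1 by methyl in place of hydrogen on a nitrogen on an aromatic ring. Neither measured step touches this nitrogen: one alters the distant aryl ether, the other the amine at the end of the chain. Among the measured compounds shown here, no measured step therefore bears directly on the present change, and the only guidance is that the two changes made so far, at either end of the shared core, produced nothing beyond the scatter. On that basis compound 4 is expected to behave much like compound 1, with a 1.0-fold lower number from compound 1 to compound 4 (0.01 log units; within the scatter) in this assay, and no direction can be assigned beyond the scatter. The estimate for compound 4 is 200000 nM, with a range from 80000 nM to 500000 nM.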

Compound 4, half-maximal inhibitory concentration: 117000 nM
Estimate against measurement, compound 4: 1.7-fold (0.23 log units) above; the measured number falls inside the stated range.
By their numbers in this assay, from the lowest: compounds 4, 2, 1 and 3 (each within the scatter of the next, the first and the last beyond it).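

In this assay, methyl in place of hydrogen on a nitrogen on an aromatic ring gives a 1.8-fold lower number from compound 1 to compound 4 (0.24 log units; within the scatter), so a third place on compound 1 has now been changed and this step, like the other two, stays within the scatter. The earlier compounds shown here all kept the hydrogen on this nitrogen, whereas compound 4 shows that losing it to a methyl does not carry the read-out beyond the scatter of compound 1, so that hydrogen is not needed for a number of this size. Nothing available bears on the reason for this result.

The compounds shown leave open whether a larger group on the same nitrogen, such as ethyl, benzyl or acetyl, would stay equally close to compound 1 or move beyond the scatter. They also leave open whether methyl on this nitrogen would give the same small step if combined with the 3-(trifluoromethyl)phenyl ether of compound 2, or with a dimethylamino group at the end of the chain.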